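Trifluoromethyl Added Where Three Compounds Showed Only Limits

A few compounds are considered here, and "the series" means these few. Any claim that something is new, unique, unknown or untested is made for them only; others in the source may bear on it.

Compound 3 `CN(CC(=O)N1CCN(c2ccccc2)CC1)C(=O)c1ccc(S(C)(=O)=O)c([N+](=O)[O-])c1` was tested in an assay on isolated protein for inhibition of thyroid hormone receptor beta (Homo sapiens), read by fluorescence polarization; on this read-out lower numbers stand for stronger inhibition and higher numbers for weaker inhibition. In this assay compound 3 gives only a limit, > 60000 nM, and no number. Compound 1 `CN(CC(=O)N1CCN(c2ccc(F)cc2)CC1)C(=O)c1ccc(S(C)(=O)=O)c([N+](=O)[O-])c1` likewise gives only the limit > 60000 nM in this assay. Compound 2 `CS(=O)(=O)c1ccc(C(=O)NCCCC(=O)N2Cc3ccccc3C2)cc1[N+](=O)[O-]` also gives only the limit > 60000 nM in this assay. Within the data shown here, the single step between measured compounds, a step that the two limits leave unreadable from compound 1 to compound 3, cannot be read because of the limit of > 60000 nM in this assay, at which 3 of the 3 values shown sit. Compound 4 `CN(CC(=O)N1CCN(c2ccc(C(F)(F)F)cc2)CC1)C(=O)c1ccc(S(C)(=O)=O)c([N+](=O)[O-])c1` differs from compound 3 by trifluoromethyl in place of hydrogen on an aromatic carbon. Among the measured compounds shown here, no measured step can be used to size this change: every value shown in this assay is a limit, so the effect of a substituent on this aromatic ring has not been seen as a number. The writer therefore expects no step beyond the scatter in this assay, and expects that compound 4 will most likely again return a limit rather than a number. Compound 4 is estimated at 70000 nM, with a range from 20000 nM to 250000 nM. The step this estimate implies is expected to be a step that the limit leaves unreadable from compound 3 to compound 4.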

Compound 4, half-maximal inhibitory concentration: > 60000 nM
Compound 4 was reported as a limit (the forecaster's own chance of this, stated with the estimate: 85%); the middle value is on the limit's open side.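

Among these compounds, compound 4, like compound 3 and compound 1, gives only a limit, so no step to compound 4 from either can be read, because of this: the limit of > 60000 nM in this assay, at which 4 of the 4 values shown sit. The compounds shown leave open whether hydrogen, fluoro or trifluoromethyl on this aromatic ring differ at all in this assay and what would bring a number there.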